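This account rests on a few compounds, and the source may have more. Where it says the series, first, only, none or still open, it means among the compounds named here.

Of the compounds shown here, three have been measured in a functional assay on the whole organism (strain Wistar) for inhibition, with Rattus norvegicus as the target, read by paw edema, with a stated time of 30 min, at a dose of 50 mg/kg by the oral route; a lower number here means less inhibition, a higher number more inhibition at the dose given (going by the name of the read-out). Compound 1, `Cc1ccc(C2=NN(c3ccc([N+](=O)[O-])cc3)C(c3cn(-c4ccccc4)nc3-c3ccc(Cl)c(Cl)c3)C2)cc1`, gives 57.4% in this assay. Compound 2, `O=CN1N=C(c2ccc(F)cc2)CC1c1cn(-c2ccccc2)nc1-c1ccc(Cl)c(Cl)c1`, gives 37.2% in this assay, and compound 3, `O=CN1N=C(c2ccc(Cl)cc2)CC1c1cn(-c2ccccc2)nc1-c1ccc(Cl)c(Cl)c1`, gives 35.1% in this assay. Compound 2 stands second highest of the three: its nearest neighbour is compound 3, with a number 2.1 percentage points lower from compound 2 to compound 3 (within the scatter) on exchanging chloro for fluoro on an aromatic carbon, while compound 1 lies further away, beyond the scatter.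

The compound still to be measured is compound 4, `CC(=O)N1N=C(c2ccc(F)cc2)CC1c1cn(-c2ccccc2)nc1-c1ccc(Cl)c(Cl)c1`. It differs from compound 2 only by methyl in place of hydrogen on a carbonyl carbon, so the formyl becomes an acetyl and all else is unchanged. Within the data shown here, none of the measured steps touches this carbonyl carbon; the only single-point step, the one from compound 2 to compound 3, concerns an aromatic halogen and therefore says nothing about the effect of a methyl here. Among the measured compounds shown here, with no step to lean on, a change of this kind is expected to leave the number within the scatter, and a number 0.8 percentage points higher from compound 2 to compound 4 (within the scatter) is the estimated step. Compound 4 is therefore expected to give 38% in this assay, within a range from 25% to 52%.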

Compound 4, a percentage reported as inhibition, in the whole organism at one dose (the size of the read-out at that dose, not a potency): 45.7%
Estimate against measurement, compound 4: 7.7 percentage points below; the range from low to high includes it.
By their numbers in this assay, from the lowest: compounds 3, 2 and 4 (each within the scatter of the next, the first and the last beyond it); then compound 1.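

In this assay, among these compounds, the carbonyl carbon on the amide-type nitrogen in a ring now has a measured step of its own, which the aromatic halogen exchange between the earlier compounds could not supply: a number 8.5 percentage points higher from compound 2 to compound 4 (within the scatter). Methyl in place of hydrogen at this carbon, turning formyl into acetyl, therefore leaves the reading within the usual scatter, so this single step shows no effect that can be told apart from repeat measurement, although it rests on one pair of compounds only. No measurement shown here bears on why the reading falls where it does.

The compounds shown leave open whether a longer chain on this carbonyl carbon, such as propanoyl, or an amine in place of the methyl would also stay within the scatter of compound 2, and whether acetyl would read alike with chloro in place of fluoro on the aromatic carbon. Compound 1, at 57.4%, differs from the acyl compounds in more than one place, so its value cannot be assigned to any single change.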